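The source may report more compounds than this note shows. Statements on the series, on what has been measured and on what is new or still open speak of the compounds shown alone.

Compounds measured in a functional assay on HEp-2 cells (Homo sapiens) for cytotoxicity, read by MTT assay, with a stated time of 72 h, tested at 5 ug/mL; on this read-out lower numbers stand for less inhibition of growth and higher numbers for more inhibition of growth at the one concentration tested:

Compound 1 `O=C1NC(=S)/C(=C/c2ccccc2Br)S1` gives 16.2%.
Compound 2 `O=C1NC(=S)/C(=C/c2ccccc2Cl)S1` gives 5.97%.
Compound 3 `O=C1NC(=S)/C(=C/c2cccc(F)c2)S1` gives 19.8%.

Compound 2 stands lowest of the three on this assay; the nearest number is that of compound 1, the furthest that of compound 3, both beyond the scatter. Compound 4 `O=C1NC(=S)/C(=C/c2ccccc2F)S1` differs from compound 2 by fluoro in place of chloro on an aromatic carbon. Going by the values given here, the one measured step that bears on this exchange is the halogen swap a number 10.2 percentage points lower from compound 1 to compound 2 (beyond the scatter), a modest drop. Among the compounds with values here, with fluoro in place of chloro the data give no direct precedent, so only a small shift, if any beyond the scatter, is expected in this assay, with the direction left open. The estimate for compound 4 is therefore 10%, in the range 0% to 22%, meaning an expected step of a number 4 percentage points higher from compound 2 to compound 4 (within the scatter).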

Compound 4, percent growth inhibition at one concentration: 8.86%
Beside the measured number, compound 4's estimate is 1.1 percentage points above it, and the stated range covers the measured number.
By their numbers in this assay, from the lowest: compounds 2, 4, 1 and 3 (each within the scatter of the next, the first and the last beyond it).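

In this assay, fluoro in place of chloro on this aromatic carbon gives a number 2.9 percentage points higher from compound 2 to compound 4 (within the scatter) and fluoro in place of bromo gives a number 7.3 percentage points lower from compound 1 to compound 4 (within the scatter) at the same place. Compound 4 therefore cannot be told apart from either compound 1 or compound 2, although those two lie beyond the scatter of each other. Nothing on hand explains this pattern.

The compounds shown leave open whether a group other than a halogen at this place, such as an amine or a methoxy group, would stay within the scatter of these numbers.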